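Removing the dimethylamino group from compound 1's chain

The source may hold more compounds than are shown below. What is called first, only, known or untested is meant among the compounds shown, and "the series" means these compounds.

Measured so far:
compound 1 `CN(C)CCCNc1nc(NCc2ccco2)c2ccccc2n1` gives 4450 nM in a functional assay on HT-29 cells (Homo sapiens) for cytotoxicity, read by MTT assay, with a stated time of 2 days; a lower number here means a stronger inhibitor, a higher number a weaker inhibitor
compound 2 `Fc1ccc2nc(NCCN3CCN(c4cccc(Cl)c4Cl)CC3)nc(NCc3ccco3)c2c1` has "not determined" (no result reported)
compound 3 `Cc1cccc(N2CCN(CCCNc3nc(NCc4ccco4)c4cc(F)ccc4n3)CC2)c1C` gives 1050 nM

Compound 1 gives the highest of the two numbers available, with compound 3 giving a lower number, a gap beyond the usual scatter. For compound 2 no number is reported. Within the data shown here, no pair differing in a single place has been measured, so no step size is yet known.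

Compound 4 `CCCCNc1nc(NCc2ccco2)c2ccccc2n1` differs from compound 1 in one place: methyl in place of dimethylamino on a saturated chain carbon, three bonds along the chain from a nitrogen on an aromatic ring The change removes the only hydrogen-bond acceptor on that chain and leaves the shared core and the furan-bearing side untouched. Nothing in the measured set tests this kind of change, so the direction cannot be read from the data. A step of modest size is expected from compound 1 to compound 4, estimated as a 1.5-fold higher number from compound 1 to compound 4 (0.16 log units; within the scatter), most likely toward a weaker inhibitor. Compound 4 is therefore expected to give about 6500 nM in this assay, within a range of 2000 nM to 22000 nM.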

Compound 4, half-maximal inhibitory concentration: 2940 nM
Compound 4: the middle estimate sits 2.2-fold (0.34 log units) above what was measured; the measured number falls inside the stated range.
By their numbers in this assay, from the lowest: compound 3; then compounds 4 and 1 (each within the scatter of the next).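

In this assay, among these compounds, the first single-place step, 3-(dimethylamino)propyl to butyl, gives a 1.5-fold lower number from compound 1 to compound 4 (0.18 log units; within the scatter). The dimethylamino group and its hydrogen-bond acceptor at this chain position are therefore not needed to keep the number within the scatter, and a plain alkyl chain serves equally well in this assay with the shared core and furan-bearing side unchanged. No measurement in hand gives a reason for this result.

Still open, from the compounds shown here alone, is whether a primary amine, a carboxylic acid or a longer chain at this position would move the number beyond the scatter. Also open, going by these compounds, is whether the same exchange on a shorter chain, 2-(dimethylamino)ethyl to propyl, would give a step of similar size.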